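Replacing a Branched Chain at the Ring Carbon

A few compounds are considered here, and "the series" means these few. Any claim that something is new, unique, unknown or untested is made for them only; others in the source may bear on it.

Compound 1 `O=C(O)c1ccc(C(=O)C2=C(O)C(=O)N(c3ccc(-c4ccon4)cc3)C2C2CCCCC2)cc1` gives 1.9 mL/min/kg in an ADME assay on the whole organism (Rattus norvegicus) for pharmacokinetics; on this read-out higher numbers stand for fast clearance and lower numbers for slow clearance.
Compound 2 `CNC(=O)c1ccc(C(=O)C2=C(O)C(=O)N(c3ccc(-c4ccon4)cc3)C2C2CCCCC2)cc1` gives 17.6 mL/min/kg in this assay.
Compound 3 `CCC(CC)C1C(C(=O)c2ccc(OC)cc2)=C(O)C(=O)N1c1ccc(-c2ccon2)cc1` gives 5.1 mL/min/kg in this assay.

Compound 3 stands second highest of the three numbers; compound 1 lies lower and compound 2 lies higher, both gaps beyond the scatter. Among the compounds with values here, the only measured step, a 9.3-fold higher number from compound 1 to compound 2 (0.97 log units; beyond the scatter), concerns a group on a carbonyl carbon elsewhere on the shared core, not the saturated ring carbon changed here, so it gives no direct guide.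

Compound 4 `COc1ccc(C(=O)C2=C(O)C(=O)N(c3ccc(-c4ccon4)cc3)C2c2ccccc2OCCO)cc1` differs from compound 3 by 2-(2-hydroxyethoxy)phenyl in place of pentan-3-yl on a saturated ring carbon. Within the data shown here, no measured pair shows this change, and the account therefore rests on compound 3 alone. Compound 4 is expected to give about 6 mL/min/kg in this assay. The estimate for compound 4 spans from 2 mL/min/kg to 20 mL/min/kg, a wide range that reflects the missing comparison. That estimate means an expected step of a 1.2-fold higher number from compound 3 to compound 4 (0.07 log units; within the scatter), which is not expected to stand clearly beyond the scatter in either direction.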

Compound 4, clearance: 67.6 mL/min/kg
The estimate for compound 4 lay 11-fold (1.05 log units) below the measured number; the whole stated range lies below it.
By their numbers in this assay, from the lowest: compound 1; then compound 3; then compound 2; then compound 4.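

Putting 2-(2-hydroxyethoxy)phenyl in place of pentan-3-yl on the saturated ring carbon gives a 13-fold higher number from compound 3 to compound 4 (1.12 log units; beyond the scatter) in this assay, so this position, untouched by the earlier measured step on a carbonyl carbon, clearly bears on the read-out. The direction is towards fast clearance, although the entering group brings an aromatic ring, an ether oxygen and a terminal hydroxy all at once, and this single step cannot tell these parts apart. No measurement shown here explains the rise.

On these data alone, it remains open whether the aromatic ring alone or its hydroxyethoxy chain carries the step, which a plain phenyl or a 2-methoxyphenyl group at this carbon would address. As far as these compounds go, it is equally open how a carboxylic acid at the end of that chain, in place of the hydroxy, would read.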